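The source may report more compounds than this note shows. Statements on the series, on what has been measured and on what is new or still open speak of the compounds shown alone.

Measured so far in an ADME assay on microsomes from liver (Homo sapiens) for metabolic stability, read by LC-MS, using NADPH, with stated times of 5 min and 30 min, tested at 1 uM; a lower number here means slower removal, a higher number faster removal of the compound:

- compound 1 `Cc1nc(CO)ccc1-c1cnc(NCc2c(F)ccc3c2CCO3)c2cn[nH]c(=O)c12` gives 11 mL.min-1.g-1
- compound 2 `Cc1ncccc1-c1cnc(NCc2c(F)ccc3c2CCO3)c2n[nH]c(=O)n12` gives 8 mL.min-1.g-1
- compound 3 `CN(C(=O)c1ccccc1)c1cnc(NCc2c(F)ccc3c2CCO3)n2cnnc12` gives > 300 mL.min-1.g-1 as a limit of the assay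

Compound 1 (11 mL.min-1.g-1) and compound 2 (8 mL.min-1.g-1) lie within the scatter of each other, so they count as one level. Compound 3 stands only as a limit (> 300 mL.min-1.g-1) and not as a number.

The next compound is compound 4 `CNC(=O)c1cc(-c2cnc(NCc3c(F)ccc4c3CCO4)c3cn[nH]c(=O)c23)n(C)n1`, in which 1-methyl-3-(methylcarbamoyl)-1H-pyrazol-5-yl takes the place of 6-(hydroxymethyl)-2-methylpyridin-3-yl on an aromatic carbon of the core of compound 1 (1-methyl-3-(methylcarbamoyl)-1H-pyrazol-5-yl in place of 6-(hydroxymethyl)-2-methylpyridin-3-yl on an aromatic carbon).

Within the data shown here, no pair of measured compounds differs in one place only, and none carries the entering group. The anchor is therefore compound 1 with 11 mL.min-1.g-1 as its value. The estimated change a 1.1-fold higher number from compound 1 to compound 4 (0.04 log units; within the scatter) in this assay stays within the scatter, with no firm direction expected. For compound 4 the estimated value is 12 mL.min-1.g-1, with an expected range of 5 mL.min-1.g-1 to 35 mL.min-1.g-1 as the likely span.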

Compound 4, intrinsic clearance in microsomes: < 3 mL.min-1.g-1
Compound 4 ended at the assay's limit (the forecaster's own chance of this, stated with the estimate: 8%); middle value at least 4.0-fold (0.60 log units) from the limit.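

Among these compounds, at the aromatic carbon of the core of compound 1, para to a large group, 1-methyl-3-(methylcarbamoyl)-1H-pyrazol-5-yl in place of 6-(hydroxymethyl)-2-methylpyridin-3-yl gives the only step that can be read in this assay: an at least 3.6-fold lower number from compound 1 to compound 4 (0.56 log units; beyond the scatter). With the core held constant, a change at this one position therefore moves the number beyond the scatter, which compounds 1, 2 and 3 could not show, as they differ in more than one place. Compound 4 gives < 3 mL.min-1.g-1, which is a limit of the assay and not a number, so the step has a lower bound only: the limit of < 3 mL.min-1.g-1 in this assay, at which 1 of the 4 values shown sits.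

The step does not separate the change of ring from the methylcarbamoyl group. A carboxylic acid or a dimethylamino group in place of the methylcarbamoyl on the same five-membered ring would bear on that question.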